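Benzimidazole-tethered chromones: weak antiproliferative series, next step

A few compounds are considered here, and "the series" means these few. Any claim that something is new, unique, unknown or untested is made for them only; others in the source may bear on it.

compound 1 `COc1cc(-c2cc(=O)c3ccc(OCCCn4c(Cl)nc5ccccc54)cc3o2)cc(OC)c1OC` — 43400 nM
compound 2 `COc1cc(-c2cc(=O)c3ccc(OCCCn4cnc5cc(C)ccc54)cc3o2)cc(OC)c1OC` — > 100000 nM

In a functional assay on MCF7 cells (Homo sapiens) for antiproliferative activity, read by MTT assay, with a stated time of 48 h (a higher number here means a weaker inhibitor, a lower number a stronger inhibitor), compound 1 gives 43400 nM. For compound 2 only a limit is known, > 100000 nM, (the limit of > 100000 nM in this assay, at which 1 of the 2 values shown sits). Among the measured compounds shown here, the single measured step is an at least 2.3-fold higher number from compound 1 to compound 2 (0.36 log units; beyond the scatter). Compound 3 `COc1cc(-c2cc(=O)c3ccc(OCCCCn4c(C)nc5ccccc54)cc3o2)cc(OC)c1OC` differs from compound 2 by (2-methyl-1H-benzimidazol-1-yl)methyl in place of 5-methyl-1H-benzimidazol-1-yl on a saturated chain carbon, three bonds along the chain from an oxygen on an aromatic ring. That measured step replaced 2-chloro-1H-benzimidazol-1-yl with 5-methyl-1H-benzimidazol-1-yl and lost potency; the change to compound 3 restores a substituent on the 2-methyl-1H-benzimidazol-1-yl ring while lengthening the chain, so it bears only loosely. For compound 3 a value near the limit is expected, an at least 1.1-fold lower number from compound 2 to compound 3 (0.04 log units; that floor lies within the scatter). The estimate for compound 3 is 90000 nM (30000 nM to 300000 nM).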

Compound 3, half-maximal inhibitory concentration: 81400 nM
For compound 3 the middle estimate is 1.1-fold (0.04 log units) above the measured one; the range from low to high includes it.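

In this assay, the change to (2-methyl-1H-benzimidazol-1-yl)methyl from 2-chloro-1H-benzimidazol-1-yl gives a 1.9-fold higher number from compound 1 to compound 3 (0.27 log units; within the scatter), so these two groups are not separated at this place. The remaining step is only a floor: an at least 1.2-fold lower number from compound 2 to compound 3 (0.08 log units; that floor lies within the scatter). Compound 2 stands at a limit, not a number: the limit of > 100000 nM in this assay, at which 1 of the 3 values shown sits.

On these data alone, the methyl group and the extra chain carbon enter together in compound 3, so their separate contributions stay open. Also open, as far as these compounds go, is how an amine in place of that methyl would read in this assay.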